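Methylating One Catechol Oxygen on a Furoxan Caffeate Ester

This account rests on a few compounds, and the source may have more. Where it says the series, first, only, none or still open, it means among the compounds named here.

The measured compounds, all in a functional assay on NCI-H157 cells (Homo sapiens) for cytotoxicity, read by resazurin assay, with a stated time of 72 h; on this read-out lower numbers stand for stronger inhibition and higher numbers for weaker inhibition:
compound 1, `O=C(/C=C/c1ccc(O)c(O)c1)OCc1c(-c2ccccc2)no[n+]1[O-]`, gives > 50000 nM, a limit of the assay rather than a number.
compound 2, `COc1cc(/C=C/C(=O)OCCCCCO[N+](=O)[O-])ccc1OCCCCCO[N+](=O)[O-]`, gives > 50000 nM, likewise a limit.
compound 3, `COc1cc(/C=C/C(=O)OCCCCCO[N+](=O)[O-])ccc1O`, gives 13400 nM.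

Compound 1 therefore stands at the limit, and it is not alone there because of the limit of > 50000 nM in this assay, at which 2 of the 3 values shown sit. Compound 4, `COc1cc(/C=C/C(=O)OCc2c(-c3ccccc3)no[n+]2[O-])ccc1O`, differs from compound 1 by methyl in place of hydrogen on an oxygen on an aromatic ring.

Going by the values given here, the only measured step, an at least 3.7-fold lower number from compound 2 to compound 3 (0.57 log units; beyond the scatter), touches the same aromatic oxygen but removes a 5-(nitrooxy)pentyl group, which is not the change from compound 1 to compound 4; no measured pair shows methyl entering in place of hydrogen on that oxygen. What the data do show is that compound 3, which carries the same 4-hydroxy-3-methoxyphenyl group as compound 4, gives a number in this assay.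

On that basis compound 4 is expected to give a measurable value, estimated at 20000 nM with a range from 5000 nM to 60000 nM. This expectation corresponds to a step of an at least 2.5-fold lower number from compound 1 to compound 4 (0.39 log units; beyond the scatter), with a fair chance that the assay again reports only a limit.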

Compound 4, half-maximal inhibitory concentration: 4530 nM
Compound 4: the middle estimate sits 4.4-fold (0.64 log units) above what was measured, and the stated range ends above it.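

Methyl in place of hydrogen on an oxygen on an aromatic ring gives, in this assay, an at least 11-fold lower number from compound 1 to compound 4 (1.04 log units; beyond the scatter), a large step for a change of a single heavy atom that turns 3,4-dihydroxyphenyl into 4-hydroxy-3-methoxyphenyl. The earlier step, an at least 3.7-fold lower number from compound 2 to compound 3 (0.57 log units; beyond the scatter), took a 5-(nitrooxy)pentyl group off an aromatic oxygen, whereas this one puts a methyl on, and both steps end on the 4-hydroxy-3-methoxyphenyl group that compound 3 and compound 4 share. Compound 1 stands at a limit of the assay, so this step has a lower bound but no upper end: the limit of > 50000 nM in this assay, at which 2 of the 4 values shown sit.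

The compounds shown leave open whether a longer chain such as ethyl on that oxygen, or a fluorine in place of the hydroxy, would give a step of the same kind, which would help to separate the part played by the entering methyl from the part played by the leaving hydroxy. They also leave open whether the same methyl step would appear with the 5-(nitrooxy)pentyl ester of compound 3 in place of the ester of compound 1.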